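The source may hold more compounds than are shown below. What is called first, only, known or untested is meant among the compounds shown, and "the series" means these compounds.

Compound 1, `Cc1ccc2[nH]c(-c3cn(-c4ccccc4)nc3-c3ccccc3)nc2c1`: 5940 nM
Compound 2, `Cc1ccc2[nH]c(-c3cn(-c4ccccc4)nc3-c3ccc(Cl)cc3)nc2c1`: 8230 nM
Compound 3, `COc1ccc(-c2nn(-c3ccccc3)cc2-c2nc3cc(Cl)ccc3[nH]2)cc1`: 1760 nM

In a functional assay on MCF7 cells (Homo sapiens) for antiproliferative activity, read by MTT assay, with a stated time of 48 h (on this read-out lower numbers stand for stronger inhibition and higher numbers for weaker inhibition), compound 1 gives 5940 nM and compound 2 gives 8230 nM. The two differ by chloro in place of hydrogen on an aromatic carbon, the chloro standing para to a large group, and the step between them is a 1.4-fold higher number from compound 1 to compound 2 (0.14 log units; within the scatter). Compound 3, built on another core, gives 1760 nM; how its core differs from that of compound 1 is not broken down here. Its number is the lowest of the three, and its gaps to compound 1 and to compound 2 are both beyond the scatter.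

Compound 4, `COc1ccc(-c2nn(-c3ccccc3)cc2-c2nc3cc(Cl)c(Cl)cc3[nH]2)cc1`, has not yet been measured in this assay. It differs from compound 3 by chloro in place of hydrogen on an aromatic carbon, here on a six-membered carbon ring that is part of a fused system, ortho to a chloro group, meta and para to a fused ring, whereas in compound 2 the chloro stands para to a large group on a phenyl. The two are therefore the same kind of change, not the same. Going by the values given here, since the one measured instance of this kind of change stayed within the scatter, compound 4 is expected to show a step of a 1.3-fold higher number from compound 3 to compound 4 (0.12 log units; within the scatter). Compound 4 is estimated at 2300 nM, between 900 nM and 6000 nM.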

Compound 4, half-maximal inhibitory concentration: 13200 nM
Compound 4: the middle estimate sits 5.7-fold (0.76 log units) below what was measured, outside the stated range (above it).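

In this assay, chloro in place of hydrogen on an aromatic carbon gives a 7.5-fold higher number from compound 3 to compound 4 (0.88 log units; beyond the scatter), a clear loss of inhibition on this core. Set beside the earlier step, the same kind of change did not carry over from one core to the other at the same size: the same change on two cores in this assay, a 1.4-fold higher number (0.14 log units; within the scatter) from compound 1 to compound 2 and a 7.5-fold higher number (0.88 log units; beyond the scatter) from compound 3 to compound 4, 5.4-fold (0.73 log units) apart, beyond the scatter of two such steps. The two steps also differ in where the chloro stands, for in compound 4 it is ortho to a chloro group on a six-membered aromatic ring that is part of a fused system, which is not its place in compound 2, so the result does not show whether the core or the place sets the size of the step, and one pair on each core gives no general rule.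

From the compounds shown here alone, whether a fluoro, a nitrile or an amine in the same place on compound 3 would give a step of like size stays open. Also open, going by these compounds, is how a chloro at this place would behave on a ring that carries no other chloro group.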